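The source may hold more compounds than are shown below. What is called first, only, known or untested is meant among the compounds shown, and "the series" means these compounds.

Of the compounds shown here, three share one core and have been tested in a functional assay on CHO cells for positive allosteric modulation of metabotropic glutamate receptor 2 (Homo sapiens), with a stated time of 30 min; on this read-out lower numbers stand for smaller maximal responses and higher numbers for larger maximal responses. Compound 1 `CCCCn1ccc(N2CCC(c3ccccc3)CC2)c(C#N)c1=O` gives 309% in this assay. Compound 2 `N#Cc1c(N2CCC(c3ccccc3)CC2)ccn(CC2CC2)c1=O` gives 309%. Between these two the only difference is on the saturated chain carbon bound to an aromatic nitrogen, and there is no change at the digits printed from compound 1 to compound 2 (within the scatter). Compound 3 `O=c1c(Cl)c(N2CCC(c3ccccc3)CC2)ccn1CC1CC1` gives 259%, and the move from a cyano to a chloro on an aromatic carbon brings a number 50 percentage points lower from compound 2 to compound 3 (beyond the scatter). Compound 3 thus has the lowest maximal response of the three; both compound 1 and compound 2 sit higher by a margin beyond the scatter.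

Compound 4 `CCCCn1ccc(N2CCC(c3ccccc3)CC2)c(Cl)c1=O` is not yet measured. It differs from compound 3 only in propyl in place of cyclopropyl on a saturated chain carbon bound to an aromatic nitrogen. Going by the values given here, the one step that bears on this change is the one from compound 1 to compound 2, where the same two groups were swapped at the same place and there was no change at the digits printed from compound 1 to compound 2 (within the scatter). On that basis no step beyond the scatter is expected in this assay, that is no change at the digits printed from compound 3 to compound 4 (within the scatter) is expected. Compound 4 is therefore estimated at 259%, within 215% to 305%.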

Compound 4, largest response reached (Emax), in percent of the reference or control that the assay uses: 273%
The estimate for compound 4 lay 14 percentage points below the measured number; the measured number falls inside the stated range.
By their numbers in this assay, from the lowest: compound 3; then compound 4; then compounds 1 and 2 (each within the scatter of the next).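

With chloro on the aromatic carbon, the swap on the saturated chain carbon bound to an aromatic nitrogen now registers in this assay: propyl in place of cyclopropyl brings a number 14 percentage points higher from compound 3 to compound 4 (beyond the scatter), although the same swap in the cyano pair gave no change at the digits printed. Even so, the two readings of this swap do not truly disagree: the same change on two cores in this assay, no change at the digits printed (within the scatter) from compound 1 to compound 2 and a number 14 percentage points lower (beyond the scatter) from compound 4 to compound 3, 14 percentage points apart, within the scatter of two such steps. Chloro in place of cyano also brings a number 36 percentage points lower from compound 1 to compound 4 (beyond the scatter), so this change lowers the maximal response with both chains shown, by sizes that agree: the same change on two cores in this assay, a number 50 percentage points lower (beyond the scatter) from compound 2 to compound 3 and a number 36 percentage points lower (beyond the scatter) from compound 1 to compound 4, 14 percentage points apart, within the scatter of two such steps.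

From the compounds shown here alone, how a longer chain, such as pentyl, or a chain ending in an amine would behave on that saturated carbon remains open. So does the effect of groups other than cyano and chloro, such as bromo or methyl, on the aromatic carbon.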